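Two Chloro Positions on an Indole-Type Core and Clearance

The source may hold more compounds than are shown below. What is called first, only, known or untested is meant among the compounds shown, and "the series" means these compounds.

Measured so far, with an ADME assay on microsomes from liver (Mus musculus) for metabolic stability, read by LC-MS (on this read-out lower numbers stand for slow clearance and higher numbers for fast clearance), as the read-out:
compound 1, `CC1CCC(NC(=O)c2cc3cc(Cl)ccc3[nH]2)CC1`, gives 122 mL.min-1.g-1
compound 2, `CC1CCC(NC(=O)c2cc3cccc(Cl)c3[nH]2)CC1`, gives 1040 mL.min-1.g-1
compound 3, `CC1CCC(NC(=O)c2cc3c(Cl)c(Cl)ccc3[nH]2)CC1`, gives 60.8 mL.min-1.g-1

Compound 1 and compound 2 share the same atoms joined differently; the difference between the two cores is not broken down here. In this assay compound 2 gives the highest of the three numbers, well beyond the scatter from both others. Compound 3 arises from compound 1 by chloro in place of hydrogen on an aromatic carbon and this gave a 2.0-fold lower number from compound 1 to compound 3 (0.30 log units; within the scatter).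

Compound 4, `CC1CCC(NC(=O)c2cc3c(Cl)ccc(Cl)c3[nH]2)CC1`, is not yet measured. It arises from compound 2 by chloro in place of hydrogen on an aromatic carbon. This is the same kind of change as from compound 1 to compound 3, but not the same: there the entering chloro group stood ortho to a chloro group, here it stands para to a chloro group.

For compound 4 the expectation is a step of a 1.7-fold lower number from compound 2 to compound 4 (0.24 log units; within the scatter), resting on the small step seen when compound 1 became compound 3, a 2.0-fold lower number from compound 1 to compound 3 (0.30 log units; within the scatter), applied to the high number of compound 2, 1040 mL.min-1.g-1. The estimate for compound 4 is therefore 600 mL.min-1.g-1, with a range from 250 mL.min-1.g-1 to 1400 mL.min-1.g-1 expected.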

Compound 4, intrinsic clearance in microsomes: 40.4 mL.min-1.g-1
Compound 4: the middle estimate sits 15-fold (1.17 log units) above what was measured; measured number below the stated range.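

In this assay, chloro in place of hydrogen on an aromatic carbon gave a 26-fold lower number from compound 2 to compound 4 (1.41 log units; beyond the scatter), a large step that leaves compound 4 with a far lower number than its parent. So the size of this change did not carry over from one core to the other, and a step read on the core of compound 1 was a poor guide to the step on the core of compound 2: the same change on two cores in this assay, a 2.0-fold lower number (0.30 log units; within the scatter) from compound 1 to compound 3 and a 26-fold lower number (1.41 log units; beyond the scatter) from compound 2 to compound 4, 13-fold (1.11 log units) apart, beyond the scatter of two such steps. Among these compounds, this rests on only two pairs, and it does not show why the steps differ: the two cores carry their first chloro at different carbons, and in compound 4 the entering chloro stands para to a chloro group, so these data cannot separate such differences.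

On these data alone, whether a fluoro, a methyl or a nitrile on the same aromatic carbon of the core of compound 2 would give a step of similar size remains open. So does whether a chloro on any other carbon of that ring would do the same.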